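One fluoro group fewer on compound 2

The compounds below may be only part of what the source reports. "The series", "measured", "known", "first", "only" and "open" are said of these compounds alone.

Compound 1 `CCC(C)(C)C(=O)N(O)Cc1cc(F)cc(F)c1F` gives 0.154 h
Compound 2 `CCC(C)(C)C(=O)N(O)Cc1cc(F)c(F)c(F)c1` gives 0.132 h

Within the data shown here, in an ADME assay on microsomes from liver (Mus musculus) for metabolic stability, read by LC-MS, using NADPH (a higher number here means that the compound lasts longer, a lower number that the compound disappears faster), compound 2 gives 0.132 h and lies within the usual scatter of compound 1 with 0.154 h as the only other measured number. Compound 3 `CCC(C)(C)C(=O)N(O)Cc1ccc(F)c(F)c1` differs from compound 2 in one place hydrogen in place of fluoro on an aromatic carbon with hydrogen in place of fluoro on an aromatic carbon. Among the measured compounds shown here, no measured pair yet shows this change alone. The expected 1.1-fold lower number from compound 2 to compound 3 (0.04 log units; within the scatter) stays within the scatter and has no clear direction. Compound 3 is estimated at 0.12 h with 0.06 h to 0.24 h as the expected range.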

Compound 3, half-life: 0.188 h
For compound 3 the middle estimate is 1.6-fold (0.19 log units) below the measured one; measured number inside the range.
By their numbers in this assay, from the lowest: compounds 2, 1 and 3 (each within the scatter of the next).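

Among these compounds, this is the first pair in which hydrogen replaces fluoro at this place, ortho to a fluoro group, meta to a fluoro group and meta to a large group. In this assay, the swap gives a 1.4-fold higher number from compound 2 to compound 3 (0.15 log units; within the scatter), which lies within the scatter, so this fluoro group can give way to hydrogen with no change that can be told from repeat variation.

As far as these compounds go, how an amine or a methoxy group at this place would fare remains open. Nothing available here explains the result.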